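Replacing 4-methylphenoxy with propyl on the chain

The source may report more compounds than this note shows. Statements on the series, on what has been measured and on what is new or still open speak of the compounds shown alone.

In a functional assay on HepG2 cells (Homo sapiens) for antiproliferative activity, read by MTT assay, with a stated time of 48 h (a lower number here means a stronger inhibitor of growth, a higher number a weaker inhibitor of growth), compound 3 `Cc1ccc(OCCCN(Cc2ccc(C(=O)NO)cc2)c2ncc(-c3ccc(C)cc3)s2)cc1` gives 12200 nM, which lies within the scatter of compound 1 `CCCCCN(Cc1ccc(C(=O)NO)cc1)c1ncc(-c2ccc(C)cc2)s1` at 7020 nM, while compound 2 `Cc1ccc(-c2cnc(N(Cc3ccccc3)Cc3ccc(C(=O)NO)cc3)s2)cc1` is clearly higher at 34000 nM. Compound 4 `CCCCCCN(Cc1ccc(C(=O)NO)cc1)c1ncc(-c2ccc(C)cc2)s1` differs from compound 3 as follows: propyl in place of 4-methylphenoxy on a saturated chain carbon, three bonds along the chain from a nitrogen on an aromatic ring. Read one bond further out, this is 3-(4-methylphenoxy)propyl to hexyl. The most relevant measured change, pentyl to that same chain, is a 1.7-fold higher number from compound 1 to compound 3 (0.24 log units; within the scatter). The steps of a 4.8-fold higher number from compound 1 to compound 2 (0.69 log units; beyond the scatter) and a 2.8-fold lower number from compound 2 to compound 3 (0.45 log units; beyond the scatter) involve phenyl and bear less directly. No change beyond the scatter is therefore expected in this assay, with the estimated 1.7-fold lower number from compound 3 to compound 4 (0.24 log units; within the scatter). For compound 4 the estimated value is 7000 nM, with an expected range from 3200 nM to 15000 nM.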

Compound 4, concentration for 50% growth inhibition: 7420 nM
The estimate for compound 4 lay 1.1-fold (0.03 log units) below the measured number, and the stated range covers the measured number.
By their numbers in this assay, from the lowest: compounds 1, 4 and 3 (each within the scatter of the next); then compound 2.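

In this assay the change to propyl at this place on the chain gives a 1.6-fold lower number from compound 3 to compound 4 (0.22 log units; within the scatter) and stays within the scatter, so the hexyl chain cannot be told apart from the chain ending in 4-methylphenoxy. With a 1.1-fold higher number from compound 1 to compound 4 (0.02 log units; within the scatter) as well, pentyl and hexyl also cannot be told apart, while a 4.6-fold lower number from compound 2 to compound 4 (0.66 log units; beyond the scatter) sets the hexyl chain clearly apart from the benzyl group of compound 2. Nothing available explains these steps. The compounds shown leave open how a chain longer than hexyl, or an amine at its end, would read.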